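Benzyl variation at the aromatic amine of compound 1

The compounds below may be only part of what the source reports. "The series", "measured", "known", "first", "only" and "open" are said of these compounds alone.

Compound 1 `Nc1cc(N)c2nc(-c3ccccc3)c(NCc3ccc(Cl)c(Cl)c3)nc2c1` is measured in a functional assay on OVCAR-4 cells (Homo sapiens) for inhibition, read by sulforhodamine B assay, with a stated time of 48 h (a lower number here means a stronger inhibitor of growth, a higher number a weaker inhibitor of growth), and its entry there is a limit of the assay, < 100000 nM, not a number. Compound 2 `CCOC(=O)[C@H](CCC(=O)O)NC(=O)c1ccc(Sc2nc3cc(N)cc(N)c3nc2-c2ccccc2)cc1` gives 53700 nM in this assay. For compound 3 `CCOC(=O)[C@H](CCC(=O)O)NC(=O)c1ccc(Oc2nc3cc(N)cc(N)c3nc2-c2ccccc2)cc1` this assay again reports only a limit, < 100000 nM. Compound 1 therefore stands as a limit, not rankable against compound 2; the limit of < 100000 nM in this assay, at which 2 of the 3 values shown sit, covers two of the three values. Compound 4 `COc1ccc(CNc2nc3cc(N)cc(N)c3nc2-c2ccccc2)cc1` differs from compound 1 by 4-methoxyphenyl in place of 3,4-dichlorophenyl on a saturated chain carbon bound to a nitrogen on an aromatic ring. Within the data shown here, with no measured step from compound 1, no change beyond the scatter is expected in this assay. Compound 4 is estimated at 50000 nM, in the range 15000 nM to 100000 nM, with a fair chance of another limit. The expected step that the limit leaves unreadable from compound 1 to compound 4 is small.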

Compound 4, concentration for total growth inhibition: 21400 nM
Compound 4: middle estimate off by 2.3-fold (0.37 log units), on the high side, within the range that was stated.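

Among these compounds, no step between compound 1 and compound 4 can be read in this assay, because compound 1 stands only as a limit: the limit of < 100000 nM in this assay, at which 2 of the 4 values shown sit. On these data alone, how 4-methoxybenzyl ranks against 3,4-dichlorobenzyl on the shared core remains open.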